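Azidomethyl in place of fluoromethyl: cytotoxicity notes

The source may report more compounds than this note shows. Statements on the series, on what has been measured and on what is new or still open speak of the compounds shown alone.

Compound 1 `Nc1ccnc2c1ncn2[C@@H]1O[C@H](CO)[C@](O)(CF)[C@H]1O` in an ADME assay on Huh-7 cells (Homo sapiens) for cytotoxicity, read by WST assay, with a stated time of 3 days (on this read-out higher numbers stand for lower toxicity in this test and lower numbers for higher toxicity in this test), gives > 100000 nM, a limit of the assay. Compound 2 `CNc1ccnc2c1ncn2[C@@H]1O[C@H](CO)[C@](O)(CF)[C@H]1O` in this assay gives > 100000 nM, likewise a limit. Compound 3 `Nc1ccn([C@@H]2O[C@H](CO)[C@](O)(CF)[C@H]2O)c(=O)n1` in this assay gives > 100000 nM, again a limit.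

Compound 2 thus stands only at a limit, with no number of its own, and the two further values shown are limits as well. Compound 4 `CNc1ccnc2c1ncn2[C@@H]1O[C@H](CO)[C@](O)(CN=[N+]=[N-])[C@H]1O` is not yet measured and differs from compound 2 by azido in place of fluoro on a saturated chain carbon bound to a saturated ring carbon. Among the compounds with values here, the one measured step in this assay, a step that the two limits leave unreadable from compound 1 to compound 2, concerns a change at a different place and is itself unreadable between two limits, so it offers no size to carry over. All three values sit together, (the limit of > 100000 nM in this assay, at which 3 of the 3 values shown sit). Within the data shown here, no measured step therefore bears on the azido for fluoro exchange, and no direction can be read from the series. Compound 4 is expected to remain at or near the same limit, with a step that the limit leaves unreadable from compound 2 to compound 4 estimated. The estimate for compound 4 is 150000 nM, with a range from 50000 nM to 600000 nM, most likely reported again only as a limit.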

Compound 4, half-maximal cytotoxic concentration: > 100000 nM
Compound 4 ended at the assay's limit; the forecaster's own chance of this, stated with the estimate: 85%; the middle value does not contradict the limit.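

Compound 2 and compound 4 both stand only at a limit in this assay, so no step between them can be read: the limit of > 100000 nM in this assay, at which 4 of the 4 values shown sit.

The compounds shown leave open where any of them would give an actual number in this assay, and so whether fluoromethyl and azidomethyl differ at all.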